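Azido nucleoside analogues: cytotoxicity on Vero cells

The source may report more compounds than this note shows. Statements on the series, on what has been measured and on what is new or still open speak of the compounds shown alone.

Measured so far in an ADME assay on Vero cells (Chlorocebus sabaeus) for cytotoxicity, with a stated time of 5 days; a lower number here means a stronger inhibitor, a higher number a weaker inhibitor:
- compound 1 `[N-]=[N+]=N[C@H]1C[C@H](n2cnc3c(NCCO)nc(N)nc32)O[C@@H]1CO`: > 100000 nM
- compound 2 `COc1nc(Cl)nc2c1ncn2[C@H]1C[C@H](N=[N+]=[N-])[C@@H](CO)O1`: > 100000 nM
- compound 3 `C=CCNc1ncnc2c1ncn2[C@H]1C[C@H](N=[N+]=[N-])[C@@H](CO)O1`: > 100000 nM

Compound 1 stands at a limit of this assay, not at a number. The value of compound 2 is likewise a limit. The value of compound 3 is a limit as well. Among the measured compounds shown here, the three values shown therefore sit together at the limit of > 100000 nM in this assay, at which 3 of the 3 values shown sit, and no step between measured compounds can be read from them.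

Compound 4 `CN(C)c1nc(N)nc2c1ncn2[C@H]1C[C@H](N=[N+]=[N-])[C@@H](CO)O1` differs from compound 1 in one place: dimethylamino in place of (2-hydroxyethyl)amino on an aromatic carbon. For the measured compounds named here, nothing among the measured compounds shows what this change does in this assay, since every value shown is a limit. Given that compound 1 gives > 100000 nM, the step from compound 1 to compound 4 is expected to be none beyond the scatter, that is a step that the limit leaves unreadable from compound 1 to compound 4. Compound 4 is therefore estimated at 150000 nM, within a range from 60000 nM to 400000 nM, and most likely reported again only as a limit.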

Compound 4, half-maximal inhibitory concentration: > 100000 nM
Compound 4 gave a limit, no number; the forecaster's own chance of this, stated with the estimate: 85%; the middle value does not contradict the limit.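

Compound 4 also gives only a limit, so no step between compound 1 and compound 4 can be read: the limit of > 100000 nM in this assay, at which 4 of the 4 values shown sit.

The compounds shown leave open whether any change on the shared core would give an actual number in this assay rather than a limit.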